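Aryl swap on the shared core: phenyl for pyridin-2-yl

The source may hold more compounds than are shown below. What is called first, only, known or untested is meant among the compounds shown, and "the series" means these compounds.

Measured compounds:
Compound 1 `Oc1cccc(-c2cc(-c3ccc(Cl)cc3)nc(-c3cccs3)c2)c1`: 11800 nM
Compound 2 `Oc1cccc(-c2cc(-c3ccc(Cl)cc3)nc(-c3ccccn3)c2)c1`: 14000 nM

In an ADME assay on HEK293 cells (Homo sapiens) for cytotoxicity, read by CCK-8 assay and cell counting, with a stated time of 2 days (on this read-out lower numbers stand for stronger inhibition and higher numbers for weaker inhibition), compound 1 gives 11800 nM and compound 2 gives 14000 nM. Compound 2 stands at the higher of the two numbers, with compound 1 nearest; the step of a 1.2-fold higher number from compound 1 to compound 2 (0.07 log units; within the scatter) lies within the scatter. Compound 3 `Oc1cccc(-c2cc(-c3ccccc3)nc(-c3ccc(Cl)cc3)c2)c1` differs from compound 2 by phenyl in place of pyridin-2-yl on an aromatic carbon. For the measured compounds named here, the one step that bears on it, a 1.2-fold higher number from compound 1 to compound 2 (0.07 log units; within the scatter), exchanged one aryl group for another at the same place and stayed within the scatter, so no step beyond the scatter is expected in this assay. Compound 3 is estimated at 13000 nM (range 6500 nM to 26000 nM), which amounts to a 1.1-fold lower number from compound 2 to compound 3 (0.03 log units; within the scatter).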

Compound 3, half-maximal inhibitory concentration: 11600 nM
The estimate for compound 3 lay 1.1-fold (0.05 log units) above the measured number; the measured number falls inside the stated range.
By their numbers in this assay, from the lowest: compounds 3, 1 and 2 (each within the scatter of the next).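

In this assay, replacing pyridin-2-yl with phenyl removes the ring nitrogen of that substituent and gives a 1.2-fold lower number from compound 2 to compound 3 (0.08 log units; within the scatter), while phenyl in place of thiophen-2-yl gives a 1.0-fold lower number from compound 1 to compound 3 (0.01 log units; within the scatter). For the compounds shown here, the position next to the ring nitrogen of the shared core has therefore now carried a carbon-only aromatic ring as well as two rings with a hetero atom, and no step between these three compounds lies beyond the scatter.

Nothing at hand explains this flat result. As far as these compounds go, whether an amine, a carboxylic acid or a longer chain at this position would give a step beyond the scatter remains open.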